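The source may hold more compounds than are shown below. What is called first, only, known or untested is meant among the compounds shown, and "the series" means these compounds.

In a functional assay (aorta) with Rattus norvegicus as the target, in the presence of a further agent that is not named here (a higher number here means that more compound is needed for the effect, a lower number that less compound is needed), compound 1 (`COC(=O)C1=C(C)N=C(C)/C(=C(/O)OC)C1c1cccc(OCc2nonc2C)c1`) gives 640 nM, compound 2 (`COC(=O)C1=C(C)N=C(C)/C(=C(/O)OC)C1c1cccc(OCc2no[n+]([O-])c2C)c1`) gives 500 nM and compound 3 (`COC(=O)C1=C(C)N=C(C)/C(=C(/O)OC)C1c1cccc(OCc2no[n+]([O-])c2C(N)=O)c1`) gives 710 nM. Compound 3 thus sits within the scatter of both others, as a 1.1-fold higher number from compound 1 to compound 3 (0.05 log units; within the scatter) and a 1.4-fold higher number from compound 2 to compound 3 (0.15 log units; within the scatter) show. The next compound is compound 4 (`COC(=O)C1=C(C)N=C(C)/C(=C(/O)OC)C1c1cccc(OCc2c(C#N)no[n+]2[O-])c1`), whose structure differs from that of compound 3 by a group of 8 heavy atoms (3 carbon, 3 nitrogen, 2 oxygen; one five-membered aromatic ring with 3 hetero atoms) in place of a group of 9 heavy atoms (3 carbon, 3 nitrogen, 3 oxygen; one five-membered aromatic ring with 3 hetero atoms), on a saturated chain carbon bound to an oxygen on an aromatic ring. For the measured compounds named here, the entering group has a triple bond outside aromatic rings, which no measured compound carries, so the data offer no direct precedent for it. The closest evidence is the set of three exchanges already measured at this place on the saturated chain carbon. Besides the two steps above, these include a 1.3-fold lower number from compound 1 to compound 2 (0.11 log units; within the scatter), and all three stay within the scatter. On these three compounds alone, no step beyond the scatter is expected in either direction. The expected step is a 1.3-fold lower number from compound 3 to compound 4 (0.11 log units; within the scatter). Compound 4 is estimated at 550 nM, with an expected range from 220 nM to 1300 nM.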

Compound 4, half-maximal effective concentration: 11 nM
Beside the measured number, compound 4's estimate is 50-fold (1.70 log units) above it; measured number outside the range, below it.
By their numbers in this assay, from the lowest: compound 4; then compounds 2, 1 and 3 (each within the scatter of the next).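

In this assay, the place on a saturated chain carbon bound to an oxygen on an aromatic ring proves far from silent: a 65-fold lower number from compound 3 to compound 4 (1.81 log units; beyond the scatter), a 45-fold lower number from compound 2 to compound 4 (1.66 log units; beyond the scatter) and a 58-fold lower number from compound 1 to compound 4 (1.76 log units; beyond the scatter) are all large, whereas every earlier exchange there stayed within the scatter. Compound 4, the only one of the four whose group has a triple bond outside aromatic rings, therefore stands clearly apart from the other three, while those three remain within the scatter of their neighbours. The exchange replaces the whole group at once, and nothing available here accounts for the size of these steps.

As far as these compounds go, whether the nitrile alone carries the large step stays open. Also open, from the compounds shown here alone, is how the same group would read with a carboxylic acid or an amine in the nitrile's place.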